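The source may report more compounds than this note shows. Statements on the series, on what has been measured and on what is new or still open speak of the compounds shown alone.

Measured so far in a physicochemical assay for lipophilicity, measured as octanol-water partition, at pH 7.4; on this read-out higher numbers stand for higher lipophilicity and lower numbers for lower lipophilicity:

- compound 1 `O=C(N[C@H]1CN(S(=O)(=O)c2ccccc2)C[C@@H]1C(=O)N[C@H]1CCCNC1)c1cn(C2CC2)cn1` gives -0.7
- compound 2 `O=C(N[C@H]1CN(S(=O)(=O)c2ccccc2)C[C@@H]1C(=O)N[C@H]1CCCNC1)c1nnc(-c2ccc(F)cc2)s1` gives 1

Of the two, compound 2 stands higher, at 1, and its gap to compound 1 lies beyond the scatter.

Next comes compound 3 `O=C(N[C@H]1CN(S(=O)(=O)c2ccccc2)C[C@@H]1C(=O)N[C@H]1CCCNC1)c1cc(-c2ccc(Cl)cc2)on1`, not yet measured. Its change from compound 2 is a group of 12 heavy atoms (9 carbon, 1 nitrogen, 1 oxygen, 1 chlorine; one five-membered aromatic ring with 2 hetero atoms, one six-membered aromatic ring of carbon only) in place of a group of 12 heavy atoms (8 carbon, 2 nitrogen, 1 fluorine, 1 sulfur; one five-membered aromatic ring with 3 hetero atoms, one six-membered aromatic ring of carbon only), on a carbonyl carbon, with 5-(4-chlorophenyl)-1,2-oxazol-3-yl as the entering group.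

Going by the values given here, only one measured step bears on this, and it is large: a number 1.70 log units higher from compound 1 to compound 2 (beyond the scatter), at the same carbonyl carbon. That step altered the size of the group, whereas here the count of heavy atoms stays the same and both groups hold a five-membered and a six-membered aromatic ring. Among the compounds with values here, no measured pair isolates a swap of this kind, so the direction is only weakly supported.

A much smaller step is therefore expected in this assay, most likely a modest rise. The estimated change is a number 0.40 log units higher from compound 2 to compound 3 (beyond the scatter) in this series. Compound 3 is expected at 1.4, with an estimated range from 0.9 to 2 for the measurement.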

Compound 3, distribution coefficient: 2.1
Compound 3: the middle estimate sits 0.70 log units below what was measured, outside the stated range (above it).
By their numbers in this assay, from the lowest: compound 1; then compound 2; then compound 3.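

In this assay, 5-(4-chlorophenyl)-1,2-oxazol-3-yl on the carbonyl carbon gives a number 1.10 log units higher from compound 2 to compound 3 (beyond the scatter), so this position responds strongly even when the heavy-atom count stays the same and both groups hold a five-membered and a six-membered aromatic ring. Against 1-cyclopropyl-1H-imidazol-4-yl, the same group gives a number 2.80 log units higher from compound 1 to compound 3 (beyond the scatter), the largest step among the three compounds, which shows that group size alone does not account for the spread in this short set. The step from compound 2 to compound 3 changes the five-membered ring and exchanges fluorine for chlorine together, and no supporting measurement bears on this result.

Because both changes travel together, the share of each in the step remains unresolved; a 4-fluorophenyl group on the same 1,2-oxazol-3-yl ring would separate them. Also open, on these data alone, is how the read-out at this position would respond to an amine or a carboxylic acid in place of the chlorine, since all three compounds carry neutral groups here.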